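The source may hold more compounds than are shown below. What is called first, only, known or untested is meant among the compounds shown, and "the series" means these compounds.

Measured in a functional assay on the whole organism with Mus musculus as the target, in the maximal electroshock model; on this read-out higher numbers stand for an effect only at larger amounts of compound and lower numbers for an effect already at smaller amounts
Compound 1 `CN1CCCC(O)(c2ccccc2)C1=O` gives 84.4 mg/kg
Compound 2 `COC1(c2ccccc2)CCCNC1=O` gives 121 mg/kg

Going by the values given here, only two numbers are available here, and they lie within the usual scatter of repeated measurements of each other. Compound 1 therefore stands level with compound 2, and neither can be ranked above the other.

The next compound, compound 3 `CCOC(=O)N1CCCC(O)(c2ccccc2)C1=O`, keeps the core of compound 1 but carries ethoxycarbonyl in place of methyl on an amide-type nitrogen in a ring. The entering group is clearly larger than the one that leaves.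

Among the compounds with values here, no pair of measured compounds shows what a change at this nitrogen does in this assay, so the data offer no direct guide to its size or direction. The starting point is the value of compound 1 (84.4 mg/kg). A modest shift toward a higher number is expected, though it may not go beyond the scatter. The estimated step of a 1.3-fold higher number from compound 1 to compound 3 (0.12 log units; within the scatter) is accordingly small, and its direction is uncertain. For compound 3 the expected value is 110 mg/kg (estimated range 50 mg/kg to 260 mg/kg).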

Compound 3, dose for half-maximal effect: 132 mg/kg
Compound 3: middle estimate off by 1.2-fold (0.08 log units), on the low side; measured number inside the range.
By their numbers in this assay, from the lowest: compounds 1, 2 and 3 (each within the scatter of the next).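

Going by these compounds alone, this is the first pair that differs in one place only, so the amide-type nitrogen in the ring can now be read directly: in this assay, ethoxycarbonyl in place of methyl gives a 1.6-fold higher number from compound 1 to compound 3 (0.19 log units; within the scatter). That step lies within the usual scatter, so compound 1 and compound 3 stand level on this read-out, even though the entering group has more heavy atoms and brings two hydrogen-bond acceptors that methyl lacks. This single pair therefore shows that the change from a small group to a clearly larger one at this nitrogen leaves no readable difference in this whole-animal test, and no measurement shown here offers an explanation for that result.

On these data alone, a single substitution cannot show how far this level result extends, so it remains open whether a longer chain such as butyl, a benzyl group or a chain ending in an amine or a carboxylic acid would also stay level on this nitrogen. As far as these compounds go, it is equally open whether ethoxycarbonyl would give a similar result on the core of compound 2, which carries a methoxy group instead of the hydroxy group.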